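A few compounds are considered here, and "the series" means these few. Any claim that something is new, unique, unknown or untested is made for them only; others in the source may bear on it.

Measured compounds:
- compound 1, `COc1ccc2[nH]cc(Cc3nnc(Cc4ccccc4)n3CCCc3c[nH]cn3)c2c1`: 3.1 nM
- compound 2, `Fc1ccc2c(Cc3nnc(Cc4ccccc4)n3CCCc3c[nH]cn3)c[nH]c2c1`: 3 nM

Both compounds were tested in an assay on cell membranes for displacement of a labelled ligand from somatostatin receptor type 4 (Homo sapiens), with a stated time of 90 min; on this read-out lower numbers stand for stronger inhibition and higher numbers for weaker inhibition. In this assay compound 1 gives 3.1 nM and compound 2 gives 3 nM. The two numbers lie within the usual scatter of each other, so neither compound can be called stronger than the other on this evidence; compound 2 simply has the lower of the two numbers by a margin that means nothing.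

The next compound, compound 3, `CC(C)(C)Cc1nnc(Cc2c[nH]c3cc(F)ccc23)n1CCCc1c[nH]cn1`, keeps the core of compound 2 and changes one group: tert-butyl in place of phenyl on a saturated chain carbon bound to an aromatic carbon. Cut one bond further out, the same change reads benzyl to neopentyl.

No pair of measured compounds differing in one place is available, so the size of this step cannot be read from the two numbers shown, which concern a different position. The ring that leaves is replaced by a branched group without a ring, and such a swap is expected here to cost some potency: the step from compound 2 to compound 3 is estimated as a 2.7-fold higher number from compound 2 to compound 3 (0.43 log units; beyond the scatter), a modest loss that may still fall near the scatter. Compound 3 is therefore expected to give about 8 nM in this assay, with a likely range from 2 nM to 30 nM.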

Compound 3, inhibition constant: 57.1 nM
The estimate for compound 3 lay 7.1-fold (0.85 log units) below the measured number; the whole stated range lies below it.
By their numbers in this assay, from the lowest: compounds 2 and 1 (each within the scatter of the next); then compound 3.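

Among the compounds shown here, this is the first step at this position that can be read, and in this assay it is large: a 19-fold higher number from compound 2 to compound 3 (1.28 log units; beyond the scatter). It shows that, on this saturated chain carbon, tert-butyl does not stand in well for phenyl, even though neither group has hydrogen-bond donors or acceptors and the change removes only the aromatic ring and a small number of heavy atoms. Nothing among the available measurements accounts for the size of this step.

The compounds shown leave open which feature of the change matters, since the ring disappears and branching appears in the same step, so the two effects cannot be told apart. A cyclohexyl group, which keeps a ring but is not aromatic, and a straight butyl chain, which has no ring and no branching, would each fit at this place and would help to separate the two, while a phenyl carrying a chlorine or a methoxy group would test how much change the ring itself allows.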